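Moving the methyl around the outer ring: compound 4

This account rests on a few compounds, and the source may have more. Where it says the series, first, only, none or still open, it means among the compounds named here.

Compound 1 `COc1ccccc1N1CCN(CCCCC(=O)NCc2ccccc2-c2ccc(Cl)cc2)CC1`: in an assay on CHO-K1 cells for displacement of a labelled ligand from 5-hydroxytryptamine receptor 7 (Homo sapiens), read by scintillation counting (a higher number here means a weaker inhibitor, a lower number a stronger inhibitor), compound 1 gives 25.9 nM.
Compound 2 `COc1ccccc1N1CCN(CCC(=O)NCc2ccccc2-c2ccccc2)CC1`: in this assay compound 2 gives 187 nM.
Compound 3 `COc1ccccc1N1CCN(CCCCC(=O)NCc2ccccc2-c2ccccc2C)CC1`: in this assay compound 3 gives 26.1 nM.

Compound 3 holds the second highest of the three numbers. Its nearest neighbour is compound 1, with a 1.0-fold higher number from compound 1 to compound 3 (0.00 log units; within the scatter), a step within the scatter. Compound 2 stands furthest away, its number beyond the scatter from that of compound 3.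

Compound 4 `COc1ccccc1N1CCN(CCCCC(=O)NCc2ccccc2-c2ccc(C)cc2)CC1` differs from compound 3 by 4-methylphenyl in place of 2-methylphenyl on an aromatic carbon. Going by the values given here, the only measured step at this position, a 1.0-fold higher number from compound 1 to compound 3 (0.00 log units; within the scatter), left the number unchanged, so exchanging one seven-carbon aromatic substituent for another is expected to move this assay little. Compound 4 is therefore estimated at 26 nM, within 12 nM to 58 nM, a step of a 1.0-fold lower number from compound 3 to compound 4 (0.00 log units; within the scatter) that is expected to stay within the scatter.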

Compound 4, inhibition constant: 66.1 nM
Compound 4: the middle estimate sits 2.5-fold (0.41 log units) below what was measured; the whole stated range lies below it.
By their numbers in this assay, from the lowest: compounds 1 and 3 (each within the scatter of the next); then compound 4; then compound 2.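

In this assay, the outer ring proves sensitive to where its methyl stands: 4-methylphenyl in place of 2-methylphenyl, with the same atoms joined differently, gives a 2.5-fold higher number from compound 3 to compound 4 (0.40 log units; beyond the scatter). Methyl in place of chloro on an aromatic carbon gives a step of similar size, a 2.6-fold higher number from compound 1 to compound 4 (0.41 log units; beyond the scatter), so the earlier level result between two substituents did not carry over to this pair. Nothing measured here explains either step.

The compounds shown leave open how an unsubstituted phenyl behaves on the longer chain. They also leave open whether methoxy or nitrile on the outer ring would follow the same course.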